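The source may hold more compounds than are shown below. What is called first, only, known or untested is meant among the compounds shown, and "the series" means these compounds.

Measured so far:
compound 1 `c1ccc(-c2cccc3c2C2CNCC3C2)cc1` — 1600 nM
compound 2 `Cc1nc2cc3c(cc2n1C)C1CNCC3C1` — 0.31 nM
compound 3 `O=S(=O)(c1ccc2c(c1)C1CNCC2C1)N1CC1` — 2 nM

In an assay on HEK293 cells for binding affinity to Neuronal acetylcholine receptor; alpha4/beta2 (Homo sapiens) (a higher number here means a weaker inhibitor, a lower number a stronger inhibitor), compound 1 stands highest of the three, with the number for compound 3 lying far below it and that of compound 2 further still, both gaps beyond the scatter. The next compound, compound 4 `Fc1cccc2c1C1CNCC2C1`, departs from compound 1 by one change: fluoro in place of phenyl on an aromatic carbon. Among the compounds with values here, no measured pair shows the same change, so its size is unknown from the data. Since the two compounds carrying only small groups on the shared core give the strongest binding, a large step downward, well beyond the scatter, is expected from compound 1 to compound 4 a 53-fold lower number from compound 1 to compound 4 (1.73 log units; beyond the scatter). Compound 4 is therefore estimated at 30 nM, within 5 nM to 200 nM.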

Compound 4, inhibition constant: 200 nM
Estimate against measurement, compound 4: 6.7-fold (0.82 log units) below; the range from low to high includes it.
By their numbers in this assay, from the lowest: compound 2; then compound 3; then compound 4; then compound 1.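

In this assay, fluoro in place of phenyl gives an 8.0-fold lower number from compound 1 to compound 4 (0.90 log units; beyond the scatter), the first step read at this aromatic carbon. It shows that the number responds to the group carried at this position, and that going from a six-carbon aromatic ring to a single fluorine has a modest effect. Nothing at hand explains this step.

On these data alone, whether hydrogen, a methoxy group or an amine at this position would shift the number further remains open. So does whether fluoro elsewhere on the shared core would give a step of similar size.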